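The compounds below may be only part of what the source reports. "The series", "measured", "known", "first", "only" and "open" are said of these compounds alone.

Compound 1 `Cc1ccc(NC(=O)Nc2ccc(Cl)cc2)cc1S(=O)(=O)N(C)C`: 3300 nM
Compound 2 `Cc1ccc(NC(=O)Nc2ccc(C)c(S(=O)(=O)N(C)C)c2)cc1Cl`: 2900 nM
Compound 3 `Cc1ccc(NC(=O)Nc2cccc(F)c2)cc1S(=O)(=O)N(C)C`: 1100 nM

In an assay on HEK293 cells for activation of Kir3.1/Kir3.2 (Homo sapiens), read by fluorescence and thallium flux, with a stated time of 4 min (on this read-out lower numbers stand for an effect already at smaller amounts and higher numbers for an effect only at larger amounts of compound), compound 3 gives the lowest number of the three, with a 2.6-fold lower number from compound 2 to compound 3 (0.42 log units; beyond the scatter) and a 3.0-fold lower number from compound 1 to compound 3 (0.48 log units; beyond the scatter) both beyond the scatter. Compound 4 `Cc1ccc(NC(=O)Nc2cccc(C#N)c2)cc1S(=O)(=O)N(C)C` differs from compound 3 by cyano in place of fluoro on an aromatic carbon, on an aromatic carbon of a six-membered aromatic ring of carbon only. Among the measured compounds shown here, no measured step swaps one small group for another at a single position: a 1.1-fold lower number from compound 1 to compound 2 (0.06 log units; within the scatter) and the two steps to compound 3 each rearrange the whole ring pattern, and they only show that such changes moved the number modestly. Compound 4 is therefore expected to land near its parent, with a 1.2-fold higher number from compound 3 to compound 4 (0.07 log units; within the scatter), and its estimate in this assay is 1300 nM, between 400 nM and 4500 nM.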

Compound 4, half-maximal effective concentration: 3900 nM
Compound 4: middle estimate off by 3.0-fold (0.48 log units), on the low side; low and high end bracket the measured number.
By their numbers in this assay, from the lowest: compound 3; then compounds 2, 1 and 4 (each within the scatter of the next).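

Among the compounds shown here, the swap of fluoro for cyano on this aromatic carbon is the first change of one small group at a single place, and in this assay it matters: a 3.5-fold higher number from compound 3 to compound 4 (0.55 log units; beyond the scatter). A group at this place is therefore not enough on its own to give the lower number of compound 3, as a 1.3-fold higher number from compound 2 to compound 4 (0.13 log units; within the scatter) and a 1.2-fold higher number from compound 1 to compound 4 (0.07 log units; within the scatter), both within the scatter. Nothing available explains the shift.

On these data alone, whether fluoro lowers the number or cyano raises it stays open. Methoxy, an amine or a bare hydrogen at this place could separate the two.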